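A single stereocentre separates compound 3 from compound 4

The compounds below may be only part of what the source reports. "The series", "measured", "known", "first", "only" and "open" are said of these compounds alone.

Values measured in a functional assay on A549 cells (Homo sapiens) for antiproliferative activity, read by XTT assay, with a stated time of 72 h (a higher number here means a weaker inhibitor, a lower number a stronger inhibitor), are as follows:
- Compound 1 `C=C(C)CCC[C@]1(C)C2=CCC[C@](C)(CC(=O)c3ccoc3)[C@H]2CC[C@H]1C` gives > 100000 nM as a limit of the assay
- Compound 2 `C=C(C)CCC[C@]1(C)C2=CCC[C@](C)(C[C@H](OC(C)=O)C3=CC(=O)OC3O)[C@H]2CC[C@H]1C` gives 4500 nM as a number
- Compound 3 `C=C(C)CCC[C@]1(C)C2=CCC[C@](C)(C[C@@H](O)C3=CC(=O)OC3O)[C@H]2CC[C@H]1C` gives 3800 nM as a number

Compound 3 and compound 2 lie within the scatter of each other, so neither can be ranked above the other. The value for compound 1 is a limit and not a number.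

The next structure is compound 4 `C=C(C)CCC[C@]1(C)C2=CCC[C@](C)(C[C@H](O)C3=CC(=O)OC3O)[C@H]2CC[C@H]1C` and its relation to compound 3 is simple: the two compounds have the same atoms and bonds; at least one stereo element is drawn with a configuration in one of them and without one in the other: 1 of 6 stereo elements differ; a stereocentre at a saturated chain carbon is drawn R in compound 3 and S in compound 4 and nothing else changes.

For the measured compounds named here, the one measured step in this small set is an at least 26-fold lower number from compound 1 to compound 3 (1.42 log units; beyond the scatter) and it is a large one. That step exchanges one group for another, however, and it does not isolate a stereocentre. Going by the values given here, no measured step here changes a stereocentre alone, so the size of such a change in this assay is not known from these data.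

The expectation therefore starts from compound 3 at 3800 nM and assumes no shift beyond the scatter, while allowing a wide margin in either direction. The expected result is a 1.2-fold higher number from compound 3 to compound 4 (0.07 log units; within the scatter) and this remains only an estimate. For compound 4 the estimated value is 4500 nM with an expected range from 1500 nM to 14000 nM in this assay.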

Compound 4, half-maximal inhibitory concentration: 3200 nM
Compound 4: middle estimate off by 1.4-fold (0.15 log units), on the high side; the measured number falls inside the stated range.
By their numbers in this assay, from the lowest: compounds 4, 3 and 2 (each within the scatter of the next). At a limit, above all of these: compound 1.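

In this assay the stereocentre at the saturated chain carbon now has a step of its own, a 1.2-fold lower number from compound 3 to compound 4 (0.07 log units; within the scatter), so at this position the change from R to S shifts the number by no more than the usual scatter of the assay. Exchanging the acetyl for hydrogen on the oxygen on this saturated carbon gives a 1.4-fold lower number from compound 2 to compound 4 (0.15 log units; within the scatter), which is also within the scatter, so neither change at this carbon separates the compounds, while the exchange of the whole group on the saturated chain carbon remains the large step, an at least 31-fold lower number from compound 1 to compound 4 (1.49 log units; beyond the scatter). The value of compound 1 is a limit and not a number: the limit of > 100000 nM in this assay, at which 1 of the 4 values shown sits.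

From the compounds shown here alone, the reading of the stereocentre also depends on how the two structures are drawn at this carbon, which leaves the stereochemical comparison open to some doubt: the fact that one of compounds 3 and 4 is drawn with a defined configuration and the other without, at the place where they differ It also remains open whether an amine or a methyl ether on this saturated carbon would move the number beyond the scatter, and whether the configuration at this carbon would then make a difference in this assay.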